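Cytotoxicity of a phenyl-bearing core with varied aryl substituents

The source may hold more compounds than are shown below. What is called first, only, known or untested is meant among the compounds shown, and "the series" means these compounds.

The account concerns a small set of compounds sharing one core and differing only in the aromatic group attached to it. Compound 1 `O=c1nc(-c2ccccc2)c2cc(-c3cccnc3)ccc2[nH]1` carries pyridin-3-yl at that position. In an ADME assay on L6 cells (Rattus norvegicus) for cytotoxicity, read by fluorescence and resazurin assay, with a stated time of 72 h (a lower number here means that less compound is needed, a higher number that more compound is needed for the effect), compound 1 gives > 50000 nM, which is a limit of the assay and not a number. Compound 2 `O=c1nc(-c2ccccc2)c2cc(-c3ccccc3F)ccc2[nH]1` carries 2-fluorophenyl, and in this assay compound 2 gives 55800 nM. Compound 3 `O=c1nc(-c2ccccc2)c2cc(-c3cn[nH]c3)ccc2[nH]1` carries 1H-pyrazol-4-yl. In this assay compound 3 gives > 50000 nM, which is again a limit. The steps among these three, a step that the limit leaves unreadable from compound 1 to compound 2, a step that the two limits leave unreadable from compound 1 to compound 3 and a step that the limit leaves unreadable from compound 2 to compound 3, cannot be sized, since the limit of > 50000 nM in this assay, at which 2 of the 3 values shown sit, covers two of the three values shown.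

Compound 4 `Cn1cc(-c2ccc3[nH]c(=O)nc(-c4ccccc4)c3c2)cn1` is the unmeasured member of the set. 1-methyl-1H-pyrazol-4-yl in place of pyridin-3-yl on an aromatic carbon

The three aryl groups measured so far all leave this assay at or near the same level, so no step in either direction beyond the scatter is expected from compound 1 to compound 4 in this assay. The step is expected to be a step that the limit leaves unreadable from compound 1 to compound 4. Compound 4 is therefore estimated to give 60000 nM in this assay, with a range from 30000 nM to 150000 nM, and most likely only a limit will be reported.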

Compound 4, half-maximal effective concentration: > 50000 nM
Compound 4: no number, only a limit (the forecaster's own chance of this, stated with the estimate: 70%); the middle value is on the limit's open side.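

In this assay compound 4 gives > 50000 nM, which is a limit of the assay and not a number. For the compounds shown here, no step between compound 4 and compound 1, compound 2 or compound 3 can be read, because the values stop at a limit: the limit of > 50000 nM in this assay, at which 3 of the 4 values shown sit. The compounds shown leave open whether these aryl groups differ at all in this assay.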